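Cytotoxicity Limits Across Three Analogues and One Untested Compound

A few compounds are considered here, and "the series" means these few. Any claim that something is new, unique, unknown or untested is made for them only; others in the source may bear on it.

Compound 1 `FC(F)(F)c1ccc(NCc2cn(-c3ccccc3)nc2-c2ccc(C(F)(F)F)cc2)cc1`: in an ADME assay on MT4 cells (Homo sapiens) for cytotoxicity, read by MTT assay, with a stated time of 96 h (on this read-out lower numbers stand for higher toxicity in this test and higher numbers for lower toxicity in this test), compound 1 gives > 100000 nM, which is a limit of the assay and not a number.
Compound 2 `FC(F)(F)c1ccc(NCc2cn(-c3ccccc3)nc2-c2ccc(Cl)cc2)cc1`: in this assay compound 2 gives > 100000 nM, also a limit of the assay.
Compound 3 `Cc1ccc(-c2nn(-c3ccccc3)cc2CNc2ccc(C(F)(F)F)cc2)cc1`: in this assay compound 3 gives > 100000 nM, again only a limit.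

Compound 4 `Cc1ccc(-c2nn(-c3ccccc3)cc2CNc2ccc(Cl)cc2)cc1` has not yet been measured. Compound 4 differs from compound 3 by chloro in place of trifluoromethyl on an aromatic carbon. The same change is made between the two measured compounds, (chloro in place of trifluoromethyl on an aromatic carbon), and the step it produced was a step that the two limits leave unreadable from compound 1 to compound 2. The two cores on which this change sits differ from each other by methyl in place of trifluoromethyl on an aromatic carbon. As the surroundings of the place are described in the same words in both cases, the change is the same one. For the step from compound 3 to compound 4 in this assay, the expected size is a step that the limit leaves unreadable from compound 3 to compound 4, standing beside the earlier step; this expectation rests on (the limit of > 100000 nM in this assay, at which 3 of the 3 values shown sit). Compound 4 is therefore estimated at about 150000 nM, with an expected range from 80000 nM to 300000 nM, and most likely the assay will again report only a limit.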

Compound 4, half-maximal cytotoxic concentration: > 100000 nM
Compound 4: a limit, no number (the forecaster's own chance of this, stated with the estimate: 85%); the middle value does not contradict the limit.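

In this assay, among the compounds shown here, compound 4 gives > 100000 nM as a limit of the assay and not a number, and no step from compound 3 to compound 4, or among compounds 1, 2 and 3, can be read. The compounds shown leave open whether trifluoromethyl, chloro or methyl changes the read-out at all, with every value at one limit: the limit of > 100000 nM in this assay, at which 4 of the 4 values shown sit.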